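The source may report more compounds than this note shows. Statements on the series, on what has been measured and on what is new or still open speak of the compounds shown alone.

Compound 3 `COc1ccc([C@H]2CC(=O)N(c3cccc(NS(=O)(=O)c4cccc(OC(F)(F)F)c4)c3)C2)cc1OC1CCCC1` is a sulfonamide on the shared core carried by compound 1 `COc1ccc([C@H]2CC(=O)N(c3cccc(C(F)(F)F)c3)C2)cc1OC1CCCC1` and compound 2 `COc1ccc([C@H]2CC(=O)N(c3cccc(S(C)(=O)=O)c3)C2)cc1OC1CCCC1`. In a functional assay on HEK293 cells (Homo sapiens) for cytotoxicity (on this read-out lower numbers stand for higher toxicity in this test and higher numbers for lower toxicity in this test), compound 3 gives only a limit, > 10000 nM. Compound 1 likewise gives only a limit, > 10000 nM. Compound 2 also reaches only a limit, > 10000 nM. Within the data shown here, the one step with both ends measured, a step that the two limits leave unreadable from compound 1 to compound 2, is unreadable, and the limit of > 10000 nM in this assay, at which 3 of the 3 values shown sit, is all the series shows. Compound 4 `COc1ccc([C@H]2CC(=O)N(c3cccc(NS(=O)(=O)c4c(F)cccc4F)c3)C2)cc1OC1CCCC1` differs from compound 3 by 2,6-difluorophenyl in place of 3-(trifluoromethoxy)phenyl on a sulfonyl sulfur. Among the measured compounds shown here, no measured step bears on the exchange of one aryl group for another on the sulfonyl sulfur, so no step beyond the scatter is expected for a step that the limit leaves unreadable from compound 3 to compound 4. Compound 4 is estimated at 15000 nM, within 5000 nM to 50000 nM, most likely again only a limit.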

Compound 4, half-maximal cytotoxic concentration: > 10000 nM
Compound 4: only a limit was reported; the forecaster's own chance of this, stated with the estimate: 80%; the middle value lies beyond the limit too.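

Among these compounds, compound 4 gives only a limit, so no step from compound 1, compound 2 or compound 3 to compound 4 can be read. Whether these four compounds differ at all in this assay stays open, as everything shown rests on one value: the limit of > 10000 nM in this assay, at which 4 of the 4 values shown sit.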